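A few compounds are considered here, and "the series" means these few. Any claim that something is new, unique, unknown or untested is made for them only; others in the source may bear on it.

Measured compounds in an ADME assay on MDBK cells (Bos taurus) for cytotoxicity, read by MTT assay, with a stated time of 96 h; a lower number here means that less compound is tolerated, a higher number that more compound is tolerated:
- compound 1 `Oc1ccc(-c2nc3cc(C(F)(F)F)ccc3[nH]2)cc1`: 51000 nM
- compound 2 `COc1ccc(-c2nc3cc(C(F)(F)F)ccc3[nH]2)cc1`: > 100000 nM

Compound 1 gives 51000 nM in this assay. For compound 2 the result > 100000 nM is a limit of the assay, not a number. Compound 2 therefore sits at the limit of > 100000 nM in this assay, at which 1 of the 2 values shown sits, and the step of an at least 1.9-fold higher number from compound 1 to compound 2 (0.29 log units; that floor lies within the scatter) is a floor only. Compound 3 `O=C(CCl)Nc1ccc(-c2nc3cc(C(F)(F)F)ccc3[nH]2)cc1` differs from compound 2 by ((chloromethyl)carbonyl)amino in place of methoxy on an aromatic carbon. Within the data shown here, no measured step covers this change; the single step measured concerns methyl in place of hydrogen and bears on it only loosely. The expected step is an at least 3.3-fold lower number from compound 2 to compound 3 (0.52 log units; beyond the scatter), toward less compound tolerated. Compound 3 is estimated at 30000 nM, within 8000 nM to 100000 nM.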

Compound 3, half-maximal cytotoxic concentration: 17000 nM
Compound 3: middle estimate off by 1.8-fold (0.25 log units), on the high side, and the stated range covers the measured number.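

With ((chloromethyl)carbonyl)amino on the aromatic carbon para to a large group, the series shows its first steps beyond the scatter in this assay, both toward less compound tolerated: an at least 5.8-fold lower number from compound 2 to compound 3 (0.76 log units; beyond the scatter), and a 3.0-fold lower number from compound 1 to compound 3 (0.48 log units; beyond the scatter). Compound 2 carries a limit and not a number, so only the second of these steps has a full measured size: the limit of > 100000 nM in this assay, at which 1 of the 3 values shown sits.

Going by these compounds, it remains open whether the chlorine or the rest of the ((chloromethyl)carbonyl)amino group carries this change. An acetylamino group or a plain amine at this position would separate the two.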